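The source may report more compounds than this note shows. Statements on the series, on what has been measured and on what is new or still open speak of the compounds shown alone.

In a functional assay on K562 cells (Homo sapiens) for antiproliferative activity, read by MTT assay, with a stated time of 24 h (on this read-out lower numbers stand for stronger inhibition and higher numbers for weaker inhibition), the measured compounds stand as follows:

Compound 1 `COc1ccc(C(=O)/C=C/c2cccc(F)c2)c2c1C=CC(C)(C)O2`: > 10000 nM, a limit of the assay rather than a number.
Compound 2 `COc1ccc(C(=O)/C=C/c2ccc(OC)c(OC)c2OC)c2c1C=CC(C)(C)O2`: > 10000 nM, likewise a limit of the assay.
Compound 3 `COc1ccc(C(=O)/C=C/c2cccc(C(F)(F)F)c2)c2c1C=CC(C)(C)O2`: 7850 nM.

Compound 1 therefore stands at the limit of > 10000 nM in this assay, at which 2 of the 3 values shown sit. Only compound 3 gives a number in this assay, and that number is itself weak. For the measured compounds named here, the single step that touches the same position is an at least 1.2-fold lower number from compound 1 to compound 3 (0.10 log units; that floor lies within the scatter), a floor that reveals no direction.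

The unmeasured compound 4 `COc1ccc(C(=O)/C=C/c2ccccn2)c2c1C=CC(C)(C)O2` differs from compound 1 by pyridin-2-yl in place of 3-fluorophenyl on a double-bonded chain carbon bound to a double-bonded chain carbon. No measured step exchanges the aromatic ring on the double-bonded chain carbon for pyridin-2-yl, so nothing among the shown steps speaks for a gain or a loss from this change. With two of three values at the limit and the third close to it, the whole shared core appears weak in this assay regardless of the ring carried on the chain.

Compound 4 is accordingly expected to remain weak, with an estimate of 12000 nM, within 4000 nM to 40000 nM. This means an expected step that the limit leaves unreadable from compound 1 to compound 4, none beyond the scatter, and a fair chance that only a limit is reported again.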

Compound 4, half-maximal inhibitory concentration: 5400 nM
For compound 4 the middle estimate is 2.2-fold (0.35 log units) above the measured one; low and high end bracket the measured number.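

The exchange of 3-fluorophenyl for pyridin-2-yl on this chain carbon gives, in this assay, an at least 1.8-fold lower number from compound 1 to compound 4 (0.26 log units; that floor lies within the scatter), so the step is only a floor and shows no gain beyond the scatter. What is new is that a ring with a hetero atom and a hydrogen-bond acceptor can stand at this place and still give a measured number, with compound 4 at 5400 nM, and that a number is no longer confined to the trifluoromethyl-bearing compound 3. Compound 1 and compound 2 nevertheless remain limits of the assay rather than numbers: the limit of > 10000 nM in this assay, at which 2 of the 4 values shown sit.

The compounds shown leave open whether the place of the ring nitrogen matters, which a pyridin-3-yl or pyridin-4-yl ring on the same chain carbon would address. Going by these compounds, they also leave open whether a phenyl ring carrying an amine or a carboxylic acid would move the shared core clearly away from this weak range, and the true size of the step from compound 1 stays unknown.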